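Shortening the side chain of compound 2

This account rests on a few compounds, and the source may have more. Where it says the series, first, only, none or still open, it means among the compounds named here.

- compound 1 `Cc1cc(N2CCCC2)nc2ccc(NC(=O)c3ccc(Cl)c(Cl)c3)cc12` gives 26300 nM
- compound 2 `Cc1cc(NCCN2CCN(C)CC2)nc2ccc(NC(=O)c3ccc(Cl)c(Cl)c3)cc12` gives 1700 nM

In a functional assay on MCF7 cells (Homo sapiens) for antiproliferative activity, read by MTT assay, with a stated time of 72 h (on this read-out lower numbers stand for stronger inhibition and higher numbers for weaker inhibition), compound 2 has the lower of the two numbers at 1700 nM, while compound 1 reads 26300 nM.

The next structure, compound 3 `Cc1cc(N2CCN(C)CC2)nc2ccc(NC(=O)c3ccc(Cl)c(Cl)c3)cc12`, has 4-methylpiperazin-1-yl in place of (2-(4-methylpiperazin-1-yl)ethyl)amino on an aromatic carbon of the shared core: 4-methylpiperazin-1-yl in place of (2-(4-methylpiperazin-1-yl)ethyl)amino on an aromatic carbon. Like compound 1, it then carries no amino chain on that carbon.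

Going by the values given here, only one measured step bears on this change. Swapping pyrrolidin-1-yl for (2-(4-methylpiperazin-1-yl)ethyl)amino gave a 15-fold lower number from compound 1 to compound 2 (1.19 log units; beyond the scatter), a large step beyond the scatter. Among the compounds with values here, it is only an indirect guide, as no measured compound has 4-methylpiperazin-1-yl on this carbon. Removing the amino chain may undo part of that gain, so a higher number is expected, though probably not all the way back to the value of compound 1. The expected step is a 4.1-fold higher number from compound 2 to compound 3 (0.61 log units; beyond the scatter). Compound 3 is estimated at 7000 nM, with an expected range of 2000 nM to 25000 nM.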

Compound 3, half-maximal inhibitory concentration: 3000 nM
For compound 3 the middle estimate is 2.3-fold (0.37 log units) above the measured one; low and high end bracket the measured number.
By their numbers in this assay, from the lowest: compounds 2 and 3 (each within the scatter of the next); then compound 1.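

In this assay the change to 4-methylpiperazin-1-yl gives a 1.8-fold higher number from compound 2 to compound 3 (0.25 log units; within the scatter) and so cannot be told apart from repeat scatter, even though the group on this aromatic carbon goes from 10 heavy atoms to 7 and from 1 hydrogen-bond donor to 0 hydrogen-bond donors. The comparison of the two groups attached directly through a ring nitrogen gives an 8.8-fold lower number from compound 1 to compound 3 (0.94 log units; beyond the scatter) for 4-methylpiperazin-1-yl in place of pyrrolidin-1-yl, so among these three compounds the lower numbers do not depend on the (2-(4-methylpiperazin-1-yl)ethyl)amino chain and go with the 4-methylpiperazine ring, which compounds 2 and 3 share. Nothing available explains why the numbers fall this way.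

A piperidin-1-yl or morpholin-4-yl ring on this carbon, or a piperazin-1-yl ring without its methyl group, would show which part of the 4-methylpiperazine ring goes with the lower number. A shorter open-chain group such as (2-(dimethylamino)ethyl)amino would show whether an amino chain without the ring can do the same.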